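A few compounds are considered here, and "the series" means these few. Any claim that something is new, unique, unknown or untested is made for them only; others in the source may bear on it.

Clearance by liver enzymes is one of the first properties followed in a compound series, and here two measurements exist. Compound 1 `O=C(NCc1cc(Cl)ccc1-n1cnnn1)[C@@H]1C[C@@H]2C[C@@H]2N1C(=O)[C@H](O)Cn1cccn1` reads < 12 mL.min-1.g-1 in an ADME assay on liver for metabolic stability, with Liver microsome (Homo sapiens) as the target, read by LC-MS, using microsomes (a higher number here means faster removal of the compound, a lower number slower removal), which is a limit of the assay and not a number. In this assay, within the data shown here, compound 2 `CC(C)(C)[C@@H](O)C(=O)N1[C@@H]2C[C@@H]2C[C@H]1C(=O)NCc1cc(Cl)ccc1-n1cnnn1` gives 54 mL.min-1.g-1, the only actual number so far.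

Compound 3 `CC(C)(C)[C@@H](O)C(=O)N1[C@H](C(=O)NCc2cc(Cl)ccc2-n2cnnn2)C[C@@H]2C[C@@H]21` has the same atoms and bonds as compound 2 and differs only in configuration as drawn, the spatial arrangement at its stereocentres: the two compounds have the same atoms and bonds and differ only in configuration as drawn: 2 of 4 stereo elements differ; a stereocentre at a saturated ring carbon is drawn R in compound 2 and S in compound 3; a stereocentre at a saturated ring carbon is drawn R in compound 2 and S in compound 3. Among the measured compounds shown here, no measured pair shows what such a change does, so the expectation starts from compound 2 at 54 mL.min-1.g-1, with no step beyond the usual scatter foreseen in either direction. The expected step is a 1.2-fold lower number from compound 2 to compound 3 (0.08 log units; within the scatter). For compound 3 the estimated clearance is 45 mL.min-1.g-1, with an expected range from 17 mL.min-1.g-1 to 110 mL.min-1.g-1.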

Compound 3, intrinsic clearance in microsomes: 75 mL.min-1.g-1
Beside the measured number, compound 3's estimate is 1.7-fold (0.22 log units) below it, within the range that was stated.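

Changing the drawn configuration at two saturated ring carbons gives, in this assay, a 1.4-fold higher number from compound 2 to compound 3 (0.14 log units; within the scatter), so this first measured change of configuration does not separate the two compounds, and the comparison is a clean one: the fact that compounds 2 and 3 differ only in the configuration as drawn. Compound 1 stands at a limit of the assay and not at a number: the limit of < 12 mL.min-1.g-1 in this assay, at which 1 of the 3 values shown sits. With tert-butyl in place of (1H-pyrazol-1-yl)methyl the reading is an at least 6.2-fold higher number from compound 1 to compound 3 (0.79 log units; beyond the scatter), so compound 3 now joins compound 2 on the faster-clearing side of compound 1, and the gap to compound 1 is not a matter of the scatter.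

Going by these compounds, what an amine or a carboxylic acid would do in the place of tert-butyl stays open. Also open, on these data alone, is whether the same change of configuration would read alike with the (1H-pyrazol-1-yl)methyl group in place.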